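Swapping a methyl for a hydroxy on a chalcone

The source may hold more compounds than are shown below. What is called first, only, known or untested is meant among the compounds shown, and "the series" means these compounds.

Among the measured compounds shown here, compound 2 `Cc1ccc(C(=O)/C=C/c2cccc(OCc3ccccc3)c2)cc1` was tested in a functional assay on PANC-1 cells (Homo sapiens) for cytotoxicity, read by MTT assay, with a stated time of 68 h (a higher number here means a weaker inhibitor, a lower number a stronger inhibitor), and gave 41600 nM, which is the higher of the two numbers measured so far. For the measured compounds named here, its only measured neighbour is compound 1 `O=C(/C=C/c1cccc(OCc2ccccc2)c1)c1cccc(Br)c1`, which in this assay gives 6400 nM. Going by the values given here, the one measured step, a 6.5-fold higher number from compound 1 to compound 2 (0.81 log units; beyond the scatter), concerns a different part of the same ring than the change now at hand, so it speaks only to how sensitive this ring is to what sits on it, not to the direction of the present change.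

Compound 3 `O=C(/C=C/c1cccc(OCc2ccccc2)c1)c1ccc(O)cc1` has not yet been measured. It differs from compound 2 in one place: hydroxy in place of methyl on an aromatic carbon. Among the compounds with values here, no measured pair shows the effect of a hydroxy in place of a methyl, so the size and direction of the step can only be guessed from the fact that the earlier ring change was modest. For compound 3 the expected step is a 1.7-fold lower number from compound 2 to compound 3 (0.22 log units; within the scatter), that is a somewhat lower number than compound 2 but well within a wide range. The estimate for compound 3 in this assay is therefore 25000 nM, between 8000 nM and 80000 nM.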

Compound 3, half-maximal inhibitory concentration: 2600 nM
Estimate against measurement, compound 3: 9.6-fold (0.98 log units) above; measured number outside the range, below it.
By their numbers in this assay, from the lowest: compound 3; then compound 1; then compound 2.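

In this assay, hydroxy in place of methyl, on a ring carbon para to a large group, gives a 16-fold lower number from compound 2 to compound 3 (1.20 log units; beyond the scatter) and so counts as a large step, whereas the earlier ring change was modest. Replacing only one heavy atom is therefore enough to shift the number strongly at this position. The 4-hydroxyphenyl ring also compares well with the 3-bromophenyl ring, with a 2.5-fold lower number from compound 1 to compound 3 (0.39 log units; beyond the scatter) as the step, which puts compound 3 lowest of the three, with its steps to both others beyond the scatter. The swap adds one hydrogen-bond donor and one hydrogen-bond acceptor by count, but nothing available explains why the number falls.

On these data alone, whether this low number belongs to hydroxy alone remains open, and a methoxy group or an amine at the same place would help to answer that. As far as these compounds go, it is also open how much of the step from the 3-bromophenyl ring comes from the change of group and how much from the change of place on the ring, since both differ at once.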